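Swapping the indole group of compound 1

The compounds below may be only part of what the source reports. "The series", "measured", "known", "first", "only" and "open" are said of these compounds alone.

Measured in a functional assay on MCF7 cells (Homo sapiens) for inhibition, read by CCK-8 assay, with a stated time of 48 h; a lower number here means a stronger inhibitor, a higher number a weaker inhibitor:
- compound 1 `COc1cc(-c2ccnc3cc(-c4c[nH]c5ccccc45)nn23)cc(OC)c1OC` gives 85 nM here
- compound 2 `Cn1ccc2cc(-c3cc4nccc(-c5ccc(F)cc5)n4n3)ccc21` gives 4580 nM here

Compound 1 has the lower of these two numbers, by a gap well beyond the scatter. Compound 3 `COc1cc(-c2ccnc3cc(-c4ccc5c(ccn5C)c4)nn23)cc(OC)c1OC` has not been measured. It differs from compound 1 in one place, with 1-methyl-1H-indol-5-yl in place of 1H-indol-3-yl on an aromatic carbon. Within the data shown here, compound 2 carries the same new group on a different remainder, so no measured pair isolates this change. The expected 1.2-fold lower number from compound 1 to compound 3 (0.08 log units; within the scatter) is none beyond the scatter in this assay, in neither direction. For compound 3 the estimate is 70 nM (expected range 12 nM to 500 nM) when tested.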

Compound 3, half-maximal inhibitory concentration: 3 nM
Beside the measured number, compound 3's estimate is 23-fold (1.37 log units) above it, outside the stated range (below it).
By their numbers in this assay, from the lowest: compound 3; then compound 1; then compound 2.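

In this assay, placing 1-methyl-1H-indol-5-yl where 1H-indol-3-yl stood gives a 28-fold lower number from compound 1 to compound 3 (1.45 log units; beyond the scatter) on the same core. This position therefore responds strongly to which indole group it carries, and the new group suits this core far better than the pairing in compound 2 alone could suggest. Nothing available explains the change.

The step joins a new attachment point with a methyl on the indole nitrogen, so neither can be credited alone. On these data alone, whether 1H-indol-5-yl or 1-methyl-1H-indol-3-yl would match compound 3 stays open.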